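Cytotoxicity of a Dimethylphenyl Analogue

This account rests on a few compounds, and the source may have more. Where it says the series, first, only, none or still open, it means among the compounds named here.

Compound 1 `Cc1cc(-c2ccccc2)cc(C)c1Nc1ccnc(Nc2ccc(C#N)cc2)n1`: 4170 nM
Compound 2 `Cc1cccc(-c2cc(C)c(Nc3ccnc(Nc4ccc(C#N)cc4)n3)c(C)c2)c1`: 3670 nM

Both numbers come from an ADME assay on MT4 cells (Homo sapiens) for cytotoxicity, read by MTT assay, with a stated time of 4 days; on this read-out lower numbers stand for higher toxicity in this test and higher numbers for lower toxicity in this test. Compound 2 and compound 1 lie within the scatter of each other, as the step of a 1.1-fold lower number from compound 1 to compound 2 (0.06 log units; within the scatter) shows. Compound 3 `Cc1cc(-c2c(C)cccc2C)cc(C)c1Nc1ccnc(Nc2ccc(C#N)cc2)n1` carries the change (2,6-dimethylphenyl in place of 3-methylphenyl on an aromatic carbon). For the measured compounds named here, the only measured step that bears on it, the addition of one methyl, was a 1.1-fold lower number from compound 1 to compound 2 (0.06 log units; within the scatter), within the scatter. A further methyl on the same ring is therefore expected to change little: a 1.0-fold lower number from compound 2 to compound 3 (0.02 log units; within the scatter). For compound 3 the expected value in this assay is 3500 nM, with a range from 1500 nM to 8000 nM.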

Compound 3, half-maximal cytotoxic concentration: 2590 nM
The estimate for compound 3 lay 1.4-fold (0.13 log units) above the measured number, within the range that was stated.
By their numbers in this assay, from the lowest: compounds 3, 2 and 1 (each within the scatter of the next).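

In this assay, putting 2,6-dimethylphenyl in place of 3-methylphenyl gives a 1.4-fold lower number from compound 2 to compound 3 (0.15 log units; within the scatter), and putting it in place of phenyl gives a 1.6-fold lower number from compound 1 to compound 3 (0.21 log units; within the scatter). Even the widest change in this set, two methyl groups added to the phenyl ring, therefore stays within the scatter, so this position accepts all three rings with no clear change in the number. Nothing measured here offers a reason for this result. Still open, from the compounds shown here alone, is whether a group of another kind at this position, such as an amine or a carboxylic acid, would move the number beyond the scatter.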